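The source may report more compounds than this note shows. Statements on the series, on what has been measured and on what is new or still open speak of the compounds shown alone.

Measured in a functional assay on MDA-MB-231 cells (Homo sapiens) for antiproliferative activity, read by MTT assay, with a stated time of 48 h; a lower number here means a stronger inhibitor, a higher number a weaker inhibitor:
- compound 1 `C=CS(=O)(=O)N1CCN(c2ncnc3sc(-c4ccc(C(F)(F)F)cc4)cc23)CC1`: 6410 nM
- compound 2 `C=CS(=O)(=O)N1CCN(c2ncnc3sc(-c4cccs4)cc23)CC1`: 34100 nM

Going by the values given here, compound 2 holds the higher of the two numbers and is the weaker inhibitor in this assay, with compound 1 its only neighbour. Compound 3 `C=CS(=O)(=O)N1CCN(c2ncnc3sc(C4=CCCCC4)cc23)CC1` is the next to be read. Its change is cyclohex-1-en-1-yl in place of thiophen-2-yl on an aromatic carbon, next to the ring sulfur.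

Among the compounds with values here, one measured step bears on this, and it concerns the same substituent: a 5.3-fold higher number from compound 1 to compound 2 (0.73 log units; beyond the scatter). That modest step shows that the group at this carbon moves the number, but no cyclohexenyl comparison exists, so direction remains a weak call. Starting from the high end of the pair, a modest move to a lower number seems likelier than a further rise. The expected step is a 2.3-fold lower number from compound 2 to compound 3 (0.36 log units; beyond the scatter). For compound 3 the estimated value is 15000 nM, with an expected range of 5000 nM to 45000 nM.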

Compound 3, half-maximal inhibitory concentration: > 50000 nM
Compound 3: no number, only a limit; the forecaster's own chance of this, stated with the estimate: 5%; at least 3.3-fold (0.52 log units) between middle value and limit.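

In this assay compound 3 reaches only a limit, not a number: the limit of > 50000 nM in this assay, at which 1 of the 3 values shown sits.

Set against thiophen-2-yl, cyclohex-1-en-1-yl gives an at least 1.4-fold higher number from compound 2 to compound 3 (0.16 log units; that floor lies within the scatter), so this step does not separate the two groups. Set against 4-(trifluoromethyl)phenyl, the same group gives an at least 7.8-fold higher number from compound 1 to compound 3 (0.89 log units; beyond the scatter), which leaves compound 1 with the lowest number of the three, its steps to both others lying beyond the scatter, and shows that a non-aromatic ring on this aromatic carbon, next to the ring sulfur, does not match the 4-(trifluoromethyl)phenyl group.

On these data alone, how far compound 3 truly lies from compound 2 stays open. Also open, as far as these compounds go, is how an unsubstituted phenyl, or a phenyl carrying an amine or a carboxylic acid, would read at this carbon.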